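A few compounds are considered here, and "the series" means these few. Any claim that something is new, unique, unknown or untested is made for them only; others in the source may bear on it.

Measured in an ADME assay on NHDF cells (Homo sapiens) for cytotoxicity, read by MTT assay, with a stated time of 72 h; a lower number here means a stronger inhibitor, a higher number a weaker inhibitor:
- Compound 1 `COc1cccc(/C=C2\CCC/C(=C\c3ccccc3Cl)C2=O)c1OC`: 44200 nM
- Compound 2 `COc1ccc(/C=C2\CCC/C(=C\c3cccc(OC)c3OC)C2=O)cc1`: 43500 nM
- Compound 3 `COc1cccc(/C=C2\CCC/C(=C\c3ccc(Cl)cc3Cl)C2=O)c1OC`: 49200 nM

Compound 3 stands level with the other two, within the scatter of both. Compound 4 `COc1cc(/C=C2\CCC/C(=C\c3cccc(OC)c3OC)C2=O)ccc1O` remains unmeasured. It differs from compound 3 as follows: 4-hydroxy-3-methoxyphenyl in place of 2,4-dichlorophenyl on a double-bonded chain carbon bound to a double-bonded ring carbon. Two measured swaps at this place bear on it: a 1.0-fold lower number from compound 1 to compound 2 (0.01 log units; within the scatter) and a 1.1-fold higher number from compound 2 to compound 3 (0.05 log units; within the scatter). Both lie within the scatter, as does the chloro addition, a 1.1-fold higher number from compound 1 to compound 3 (0.05 log units; within the scatter). Among the measured compounds shown here, no measured compound carries the 4-hydroxy-3-methoxyphenyl group, so the evidence is indirect. No change beyond the scatter is expected, and the expected step is a 1.2-fold lower number from compound 3 to compound 4 (0.09 log units; within the scatter). For compound 4 the estimated value is 40000 nM, with an expected range from 20000 nM to 70000 nM.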

Compound 4, half-maximal inhibitory concentration: 14300 nM
Beside the measured number, compound 4's estimate is 2.8-fold (0.45 log units) above it; measured number outside the range, below it.
By their numbers in this assay, from the lowest: compound 4; then compounds 2, 1 and 3 (each within the scatter of the next).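

In this assay, swaps at this position had moved the number only within the scatter, but 4-hydroxy-3-methoxyphenyl gives steps beyond it (a 3.4-fold lower number from compound 3 to compound 4 (0.54 log units; beyond the scatter)) (a 3.0-fold lower number from compound 2 to compound 4 (0.48 log units; beyond the scatter)) (a 3.1-fold lower number from compound 1 to compound 4 (0.49 log units; beyond the scatter)). These steps run the same way whether 2,4-dichlorophenyl, 4-methoxyphenyl or 2-chlorophenyl leaves, so the position is not indifferent to its group. Nothing measured here accounts for the shift. Still open, from the compounds shown here alone, is whether a 4-hydroxyphenyl group alone would give the same step, or whether an amine in place of the hydroxy would keep it.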